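The source may report more compounds than this note shows. Statements on the series, on what has been measured and on what is new or still open speak of the compounds shown alone.

The measured compounds and their numbers:

compound 1, `CNC(=O)/C=C/c1ccncc1-c1ccc2cccnc2c1`, 82%
compound 2, `O=C(O)[C@@H]1CCCN1C(=O)/C=C/c1ccncc1-c1ccc2ccccc2c1`, 67%
compound 3, `NNC(=O)CCc1ccncc1-c1ccc2ccccc2c1`, 102%

All three were tested in an assay on a protein complex for inhibition of CDK8/Cyclin C (Homo sapiens), with a stated time of 1 h, tested at 10 uM; a lower number here means less inhibition, a higher number more inhibition at the concentration tested (going by the name of the read-out). Compound 3 stands highest of the three: in this assay compound 3 gives 102%, which lies beyond the scatter above compound 1 and, by a wider margin, beyond the scatter above compound 2. No change between two measured compounds has been followed in a single place, so none of the three gaps can be tied to a single structural step.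

The next compound is compound 4, `O=C(O)COc1ccncc1-c1ccc2ccccc2c1`, which has not yet been measured in this assay. Compared with compound 3 it differs in one place: carboxymethoxy in place of 2-(aminocarbamoyl)ethyl on an aromatic carbon. The leaving group and the entering group both carry one double bond outside aromatic rings and are of similar size.

Without a measured step of this kind, the expectation rests on the three numbers alone. Of the three, compound 2 carries a carboxyl group and gives the lowest number, 67%, and compound 4 also brings a carboxyl group in its carboxymethoxy. The step of a number 32 percentage points lower from compound 3 to compound 4 (beyond the scatter) is therefore expected to be downward and beyond the scatter. For compound 4 in this assay the estimate is 70%, with a range from 40% to 95%.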

Compound 4, a percentage reported as inhibition, at one concentration (the size of the read-out at that concentration, not a potency): 16%
Beside the measured number, compound 4's estimate is 54 percentage points above it, outside the stated range (below it).
By their numbers in this assay, from the lowest: compound 4; then compound 2; then compound 1; then compound 3.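

In this assay, the aromatic carbon opposite the ring nitrogen, ortho to a large group, proves highly sensitive to the group it carries: a number 86 percentage points lower from compound 3 to compound 4 (beyond the scatter), a large step, with carboxymethoxy in place of 2-(aminocarbamoyl)ethyl. Going by these compounds alone, this is the first change followed in a single place, and it shows that two open-chain groups of similar size, each with one double bond outside aromatic rings and neither with a net charge, can still give very different read-outs, so those shared counts do not settle the outcome at this position. Nothing measured here offers an explanation for the size of this step.

As far as these compounds go, the exchange replaces the whole chain at once, so it remains open whether the step follows from the ether oxygen joining carboxymethoxy to the ring, from the carboxylic acid at its end, or from the loss of the aminocarbamoyl end. A carboxylic acid on an all-carbon chain, a methyl ester of the same carboxymethoxy group, or a simple primary amide at this position would begin to separate these parts.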